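Phenoxy in place of 4-fluorophenyl in the acid series

The source may hold more compounds than are shown below. What is called first, only, known or untested is meant among the compounds shown, and "the series" means these compounds.

Within the data shown here, compound 2 `Cc1n[nH]c(C(=O)O)c1Cc1ccccc1-c1ccc(F)cc1` gives 56% in an assay on isolated protein for inhibition of 2-Hydroxyacid oxidase 2 (Homo sapiens), tested at 10 uM (on this read-out lower numbers stand for a weaker effect and higher numbers for a stronger effect at the one concentration tested), and stands highest of the three numbers known. Its nearest neighbour is compound 1 `Cc1n[nH]c(C(=O)O)c1Cc1cccc(-c2cccc(F)c2)c1`, which gives 50% in this assay, a gap within the scatter. Its furthest is compound 3 `Cc1n[nH]c(C(=O)O)c1Cc1cccc(-c2ccccc2F)c1`, which gives 22% in this assay, a gap beyond the scatter. Among the measured compounds shown here, the one measured step with a single change is a number 28 percentage points lower from compound 1 to compound 3 (beyond the scatter); it moves only the fluorine between ring positions and leaves the link between the two rings as it is.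

Compound 4 `Cc1n[nH]c(C(=O)O)c1Cc1ccccc1Oc1ccccc1` carries phenoxy in place of 4-fluorophenyl on an aromatic carbon. For the measured compounds named here, no measured step alters the link between the two rings or removes the fluorine, so the step from compound 1 to compound 3 does not bear on this change, and no direction can be drawn from it. The expected step is therefore uncertain and set, as an estimate, at a number 16 percentage points lower from compound 2 to compound 4 (beyond the scatter), with a wide range. Compound 4 is expected to give 40% in this assay, between 15% and 65%.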

Compound 4, a percentage reported as inhibition, at one concentration (the size of the read-out at that concentration, not a potency): 49%
Compound 4: middle estimate off by 9 percentage points, on the low side, and the stated range covers the measured number.
By their numbers in this assay, from the lowest: compound 3; then compounds 4, 1 and 2 (each within the scatter of the next).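

In this assay, among these compounds, phenoxy in place of 4-fluorophenyl on an aromatic carbon, ortho to a large group, gives a number 7 percentage points lower from compound 2 to compound 4 (within the scatter) and is the only measured step that alters how the two rings are joined and removes the fluorine. At this position, phenoxy, with one hydrogen-bond acceptor, and 4-fluorophenyl, with none, therefore read alike at the one concentration tested. No measurement on hand accounts for this result.

Going by these compounds, the step alters the joining atom and removes the fluorine together, so the share of each remains open; a 4-fluorophenoxy group or an unsubstituted phenyl would separate them. Also open, on these data alone, is how a benzyloxy group or an anilino group, with an amine nitrogen joining the rings, would read at this position.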